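Amide replacement in a shared core: toxicity toward THP-1 cells

This account rests on a few compounds, and the source may have more. Where it says the series, first, only, none or still open, it means among the compounds named here.

Compound 1, `COc1ccc(-c2cnc(NC(=O)c3cnc[nH]3)n2C)cc1`, gives > 100000 nM in a toxicity assay on THP-1 cells (Homo sapiens) for inhibition (a higher number here means that more compound is tolerated, a lower number that less compound is tolerated), a limit of the assay.
Compound 2, `COc1ccc(-c2cnc(NC(=O)c3cccc(O)c3)n2C)cc1`, gives > 100000 nM in this assay, again a limit.
Compound 3, `COc1ccc(-c2cnc(NC(=O)c3cccc(OC)c3)n2C)cc1`, gives > 100000 nM in this assay, also a limit.

Compound 3 therefore stands at the limit shared by all three measured compounds, as stated in the limit of > 100000 nM in this assay, at which 3 of the 3 values shown sit. The steps a step that the two limits leave unreadable from compound 1 to compound 2, a step that the two limits leave unreadable from compound 1 to compound 3 and a step that the two limits leave unreadable from compound 2 to compound 3 are all unreadable, since both ends sit at the limit.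

Compound 4, `COc1ccc(-c2cnc(NC(=O)c3ccc(Cl)cc3)n2C)cc1`, differs from compound 3 as 4-chlorophenyl in place of 3-methoxyphenyl on a carbonyl carbon. Among the measured compounds shown here, none of the measured steps can be read, so no size or direction can be taken from them; they show only that each group placed on the carbonyl carbon so far left the compound tolerated up to the limit. For the measured compounds named here, the expectation for compound 4 is therefore a step of a number no higher from compound 3 to compound 4 (the limit leaves the size open) that is no step at all beyond the scatter. Compound 4 is expected to give 100000 nM in this assay, within 40000 nM to 300000 nM, most likely reported again as a limit.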

Compound 4, half-maximal cytotoxic concentration: > 100000 nM
Compound 4 ended at the assay's limit; the forecaster's own chance of this, stated with the estimate: 80%; the middle value lies on the limit itself.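

Compound 4 sits at the same limit as compound 1, compound 2 and compound 3, so none of the steps from those three compounds to compound 4 can be read: the limit of > 100000 nM in this assay, at which 4 of the 4 values shown sit.

The compounds shown leave open how much of each is tolerated in this assay, and whether any group on the carbonyl carbon would give a value inside the assay's range.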